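Aryl replacement at the chain carbon of the piperazine amides

This account rests on a few compounds, and the source may have more. Where it says the series, first, only, none or still open, it means among the compounds named here.

In an assay on isolated protein for binding affinity to somatostatin receptor type 3 (Homo sapiens) (a lower number here means tighter binding, a higher number weaker binding), compound 2 `Cc1nc2cc(C[C@H](C)CN3C[C@@H]4CCCC[C@@H]4[C@H](C(=O)N4CCN(c5ccc(F)c(F)c5)CC4)C3)ccc2o1` gives 3.39 nM, the second highest of the three numbers; compound 1 `COC(=O)c1cc(CC(C)CN2CC3CCCCC3C(C(=O)N3CCN(c4ccc([N+](=O)[O-])cc4)CC3)C2)cc(C(=O)OC)c1` gives 2.88 nM, within the scatter of compound 2, and compound 3 `C[C@@H](Cc1ccc2nccnc2c1)CN1C[C@@H]2CCCC[C@@H]2[C@H](C(=O)N2CCN(c3ccc(F)c(F)c3)CC2)C1` gives 10.7 nM. Going by the values given here, the single step at this place, a 3.2-fold higher number from compound 2 to compound 3 (0.50 log units; beyond the scatter), shows that exchanging the aromatic group on the chain carbon weakened binding modestly. Compound 4 `CCNc1ccc(C[C@H](C)CN2C[C@@H]3CCCC[C@@H]3[C@H](C(=O)N3CCN(c4ccc(F)c(F)c4)CC3)C2)cn1` carries 6-(ethylamino)pyridin-3-yl in place of 2-methyl-1,3-benzoxazol-5-yl on a saturated chain carbon, three bonds along the chain from an amine nitrogen in a ring. Among the compounds with values here, no measured step covers this incoming group; the step to compound 3 is the only guide, and it points toward a weaker number. A step of about a 2.1-fold higher number from compound 2 to compound 4 (0.31 log units; beyond the scatter) is therefore expected, weaker beyond the scatter but not large. Compound 4 is estimated at 7 nM, with a range from 2.5 nM to 20 nM.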

Compound 4, dissociation constant: 28.8 nM
For compound 4 the middle estimate is 4.1-fold (0.61 log units) below the measured one; the measured number lies above the stated range.
By their numbers in this assay, from the lowest: compounds 1 and 2 (each within the scatter of the next); then compound 3; then compound 4.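

Putting 6-(ethylamino)pyridin-3-yl on this saturated chain carbon gives an 8.5-fold higher number from compound 2 to compound 4 (0.93 log units; beyond the scatter) in this assay, a larger loss than a 3.2-fold higher number from compound 2 to compound 3 (0.50 log units; beyond the scatter), and the direct comparison gives a 2.7-fold higher number from compound 3 to compound 4 (0.43 log units; beyond the scatter). Neither replacement of 2-methyl-1,3-benzoxazol-5-yl matches compound 2, and the two replacements differ from each other beyond the scatter. No measured evidence on the result is at hand.

Open, on these data alone, is whether the ethylamino group itself carries the loss. A plain pyridin-3-yl or a 6-methoxypyridin-3-yl at this carbon would test that.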